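This account rests on a few compounds, and the source may have more. Where it says the series, first, only, none or still open, it means among the compounds named here.

The three measured compounds, all tested in a functional assay on CCRF-CEM cells (Homo sapiens) for cytotoxicity, in the presence of a further agent that is not named here; a higher number here means a weaker inhibitor, a lower number a stronger inhibitor:

- compound 1 `Nc1nc(N)c(CCCN(Cc2ccc(NC(CCC(=O)O)C(=O)O)cc2)c2cc(F)c([N+](=O)[O-])cc2[N+](=O)[O-])c(O)n1` gives 43000 nM
- compound 2 `COC(=O)c1ccc(CN(CCCc2c(N)nc(N)nc2O)c2cc(F)c([N+](=O)[O-])cc2[N+](=O)[O-])cc1` gives 3500 nM
- compound 3 `Nc1nc(N)c(CCCN(Cc2ccc(NC(CCC(=O)O)C(=O)O)cc2)c2ccc([N+](=O)[O-])c(F)c2F)c(O)n1` gives > 100000 nM

Compound 2 differs from compound 1 in one place: methoxycarbonyl in place of (1,3-dicarboxypropyl)amino on an aromatic carbon. That single exchange made a large step, a 12-fold lower number from compound 1 to compound 2 (1.09 log units; beyond the scatter), so the smaller ester-bearing group gave the stronger inhibitor of the two.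

Compound 3 carries a different core from compound 1; the difference between the two cores is not broken down here. For compound 3 the value is not a number but a limit, (the limit of > 100000 nM in this assay, at which 1 of the 3 values shown sits), so its true potency is known only to lie at or beyond that edge.

Compound 4 `COC(=O)c1ccc(CN(CCCc2c(N)nc(N)nc2O)c2ccc([N+](=O)[O-])c(F)c2F)cc1` has not yet been measured. It stands to compound 3 exactly as compound 2 stands to compound 1: methoxycarbonyl in place of (1,3-dicarboxypropyl)amino on an aromatic carbon. The surroundings of the exchange are described in the same words for both pairs, so this is the same change, made on the core of compound 3.

The step from compound 3 to compound 4 in this assay is expected to be of a size near an at least 4.0-fold lower number from compound 3 to compound 4 (0.60 log units; beyond the scatter), resting on the earlier step of a 12-fold lower number from compound 1 to compound 2 (1.09 log units; beyond the scatter). Since compound 3 sits at the limit (the limit of > 100000 nM in this assay, at which 1 of the 3 values shown sits), its starting point is uncertain, and the estimate for compound 4 is correspondingly wide. Compound 4 is estimated at 25000 nM, with a likely range from 6000 nM to 100000 nM.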

Compound 4, half-maximal inhibitory concentration: 45000 nM
Beside the measured number, compound 4's estimate is 1.8-fold (0.26 log units) below it; the measured number falls inside the stated range.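

Putting methoxycarbonyl in place of (1,3-dicarboxypropyl)amino on the core of compound 3 gave, in this assay, an at least 2.2-fold lower number from compound 3 to compound 4 (0.34 log units; beyond the scatter). The result for compound 3, recorded as > 100000 nM, is a limit of the assay and not a number. The exchange therefore lowers the number on both cores shown, which supports its direction carrying over between these two cores, but this does not show that the size of the step carries over or that the same would hold on any other core in the series: the same change on two cores in this assay, a 12-fold lower number (1.09 log units; beyond the scatter) from compound 1 to compound 2 and an at least 2.2-fold lower number (0.34 log units; beyond the scatter) from compound 3 to compound 4; the limit leaves it open whether they differ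

The compounds shown place only these two groups at this position, so it remains open how a simple carboxylic acid or an amide would compare there with methoxycarbonyl or (1,3-dicarboxypropyl)amino. Among the compounds shown here, it also remains open whether the exchange would lower the number in the same way on a core with a longer chain in place of the one shared by these compounds.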